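This account rests on a few compounds, and the source may have more. Where it says the series, first, only, none or still open, it means among the compounds named here.

Measured compounds:
- compound 1, `Cc1nsc2c1ncn2[C@H]1C[C@H](O)[C@@H](CO)O1` — > 100000 nM
- compound 2, `CSc1nc2c(C)nsc2n1[C@H]1C[C@H](O)[C@@H](CO)O1` — > 100000 nM
- compound 3, `Cc1nsc2c1nc(SCc1ccccc1)n2[C@H]1C[C@H](O)[C@@H](CO)O1` — > 100000 nM

All three were tested in a functional assay on HFF cells (Homo sapiens) for inhibition; on this read-out lower numbers stand for stronger inhibition and higher numbers for weaker inhibition. In this assay compound 1 gives > 100000 nM, which is a limit of the assay and not a number. Compound 2 and compound 3 sit at the same limit, so compound 1 stands nowhere distinct: it rests on the limit of > 100000 nM in this assay, at which 3 of the 3 values shown sit, together with every other value shown. The three measured steps, a step that the two limits leave unreadable from compound 1 to compound 2, a step that the two limits leave unreadable from compound 1 to compound 3 and a step that the two limits leave unreadable from compound 2 to compound 3, all concern groups on the aromatic carbon of the shared core and none of them yields a readable size.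

Compound 4, `Cc1nsc2c1ncn2[C@@H]1O[C@H](CO)[C@@H](O)[C@@H]1O`, differs from compound 1 by hydroxy in place of hydrogen on a saturated ring carbon. Within the data shown here, no measured step touches that part of the molecule, so nothing among the data bears directly on this change, and the only guide is that compound 1 itself is at the limit. Compound 4 is therefore expected to stay at the limit as well, with a number no higher from compound 1 to compound 4 (the limit leaves the size open) as the estimated step. The estimate for compound 4 in this assay is 100000 nM, within 30000 nM to 300000 nM.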

Compound 4, half-maximal inhibitory concentration: > 100000 nM
Compound 4 ended at the assay's limit (the forecaster's own chance of this, stated with the estimate: 85%); the middle value sits exactly at the limit.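

Compound 4 rests at the same limit of the assay as compound 1, so the step between them cannot be read and no new step follows: the limit of > 100000 nM in this assay, at which 4 of the 4 values shown sit.

The compounds shown leave open the size of every change among them in this assay, as none of them gives a readable number.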